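The compounds below may be only part of what the source reports. "The series", "measured", "known", "first", "only" and "open" are said of these compounds alone.

Compound 1 `CCc1nc(N)nc(N)c1-c1ccc(NCc2ccc(S(C)(=O)=O)cc2)cc1`: 7.4 nM
Compound 2 `CCc1nc(N)nc(N)c1-c1ccc(NCc2ccc([N+](=O)[O-])cc2)cc1`: 11 nM
Compound 3 `CCc1nc(N)nc(N)c1-c1ccc(CNc2ccc([N+](=O)[O-])cc2)cc1`: 9.2 nM

All three were tested in an in vitro assay on CHOK cells for displacement of a labelled ligand from growth hormone secretagogue receptor type 1 (Homo sapiens); a higher number here means a weaker inhibitor, a lower number a stronger inhibitor. Compound 2 and compound 3 are built from the same atoms joined differently; the difference between their two cores is not broken down here, and their two numbers lie within the usual scatter of each other. Compound 1 arises from compound 2 by a single change, (methylsulfonyl in place of nitro on an aromatic carbon), and the result was a 1.5-fold lower number from compound 2 to compound 1 (0.17 log units; within the scatter). Compound 4 `CCc1nc(N)nc(N)c1-c1ccc(CNc2ccc(S(C)(=O)=O)cc2)cc1` has not yet been measured; it arises from compound 3 by the same change, (methylsulfonyl in place of nitro on an aromatic carbon), at the same place. Because the earlier step of a 1.5-fold lower number from compound 2 to compound 1 (0.17 log units; within the scatter) was small, a step of similar size is expected here, about a 1.4-fold lower number from compound 3 to compound 4 (0.15 log units; within the scatter). Compound 4 is therefore estimated at 6.5 nM, most likely lying between 3 nM and 14 nM.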

Compound 4, half-maximal inhibitory concentration: 9.8 nM
The estimate for compound 4 lay 1.5-fold (0.18 log units) below the measured number; the range from low to high includes it.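

In this assay, among these compounds, methylsulfonyl in place of nitro gave a 1.1-fold higher number from compound 3 to compound 4 (0.03 log units; within the scatter), so on this second core, as on the first, the swap produces no step that can be told from repeat-measurement noise. Set side by side, the two steps agree as far as such measurements can tell: the same change on two cores in this assay, a 1.5-fold lower number (0.17 log units; within the scatter) from compound 2 to compound 1 and a 1.1-fold higher number (0.03 log units; within the scatter) from compound 3 to compound 4, 1.6-fold (0.20 log units) apart, within the scatter of two such steps. This suggests that the swap carries between these two cores without a detectable penalty, but two small steps cannot show that it has any real effect of its own, nor that it would behave alike on any further core.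

The compounds shown leave open how a quite different group in the same place, such as an amine or a carboxylic acid, would fare. They also leave open whether either core would then respond in the same way.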